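A Pyridine Swap at the Assay Limit

The source may hold more compounds than are shown below. What is called first, only, known or untested is meant among the compounds shown, and "the series" means these compounds.

In a toxicity assay on HepG2 2.2.15 cells (Homo sapiens) for cytotoxicity, read by CellTiter-Glo (a lower number here means that less compound is tolerated, a higher number that more compound is tolerated), compound 1 (`O=C1OC(c2ccccc2)CN1c1cnn2c1CN(C(=O)Nc1cc(F)c(F)c(F)c1)C(C1CC1)C2`) gives 7410 nM and compound 2 (`O=C1c2ccccc2CN1c1cnn2c1CN(C(=O)Nc1cc(F)c(F)c(F)c1)C(C1CC1)C2`) gives 38500 nM on the same scale. Compound 3 (`O=C1CC(c2ncccn2)CN1c1cnn2c1CN(C(=O)Nc1cc(F)c(F)c(F)c1)C(C1CC1)C2`) stands at > 200000 nM as a limit of the assay, not a number. Compound 4 (`O=C1CC(c2ccccn2)CN1c1cnn2c1CN(C(=O)Nc1cc(F)c(F)c(F)c1)C(C1CC1)C2`) differs from compound 3 by pyridin-2-yl in place of pyrimidin-2-yl on a saturated ring carbon with pyridin-2-yl in place of pyrimidin-2-yl on a saturated ring carbon. Among the measured compounds shown here, two measured steps bear on this: an at least 26-fold higher number from compound 1 to compound 3 (1.43 log units; beyond the scatter) is large and an at least 5.1-fold higher number from compound 2 to compound 3 (0.71 log units; beyond the scatter) is at least modest, and each swaps a whole group. Compound 2, with its carbon-only aromatic ring, sits at 38500 nM and pyridin-2-yl goes one hetero atom toward that count, so a modest step down in this assay is expected. Another limit reading is also possible for compound 4. For compound 4 the estimated value is 90000 nM within 25000 nM to 200000 nM as the expected range. The estimate means an at least 2.2-fold lower number from compound 3 to compound 4 (0.34 log units; beyond the scatter) as the expected step.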

Compound 4, half-maximal cytotoxic concentration: 96200 nM
Compound 4: middle estimate off by 1.1-fold (0.03 log units), on the low side, within the range that was stated.
By their numbers in this assay, from the lowest: compound 1; then compound 2; then compound 4. At a limit, above all of these: compound 3.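

In this assay, among the compounds shown here, pyridin-2-yl in place of pyrimidin-2-yl on this saturated ring carbon gives an at least 2.0-fold lower number from compound 3 to compound 4 (0.31 log units; beyond the scatter), the first step at this position that changes the aromatic ring alone. Its full size cannot be read, since compound 3 stands only at a limit: the limit of > 200000 nM in this assay, at which 1 of the 4 values shown sits. Compound 4 also gives a number that places this 2-oxo-4-(pyridin-2-yl)pyrrolidin-1-yl group against the others, with a 2.5-fold higher number from compound 2 to compound 4 (0.40 log units; beyond the scatter) and a 13-fold higher number from compound 1 to compound 4 (1.11 log units; beyond the scatter).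

As far as these compounds go, whether phenyl at this ring carbon would lower the number further remains open. So does what an amine or a carboxylic acid there would do.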